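The compounds below may be only part of what the source reports. "The series", "measured", "known", "first", "only" and "open" are said of these compounds alone.

In a functional assay with Oryctolagus cuniculus as the target (a higher number here means a weaker inhibitor, a lower number a stronger inhibitor), compound 1 `COc1ccc(-c2nc(CN)sc2-c2ccc(OC)cc2)cc1` gives > 100 nM, which is a limit and not a number. Among the compounds with values here, compound 2 `COc1ccc(-c2nc(CNC(=O)N3CCOCC3)sc2-c2ccc(OC)cc2)cc1` gives 660 nM, the only true number so far, so its standing against compound 1 cannot be read. The change followed here leads to compound 3 `COc1ccc(-c2nc(C(N)=O)sc2-c2ccc(OC)cc2)cc1`: carbamoyl in place of (((morpholin-4-yl)carbonyl)amino)methyl on an aromatic carbon. In words, carbamoyl takes the place of (((morpholin-4-yl)carbonyl)amino)methyl on an aromatic carbon. Within the data shown here, the only measured step, a step that the limit leaves unreadable from compound 1 to compound 2, has no readable size, as the limit of > 100 nM in this assay, at which 1 of the 2 values shown sits, shows, and it is a different change, so it offers no measured guide to size or direction. With nothing to argue for a shift in this assay, the expected step of a 1.1-fold lower number from compound 2 to compound 3 (0.04 log units; within the scatter) is none beyond the scatter, though the uncertainty is wide. For compound 3 the estimated value is 600 nM, with an expected range from 150 nM to 2500 nM.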

Compound 3, half-maximal inhibitory concentration: > 1000 nM
Compound 3 ended at the assay's limit (the forecaster's own chance of this, stated with the estimate: 25%); middle value at least 1.6-fold (0.22 log units) from the limit.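

In this assay, carbamoyl in place of (((morpholin-4-yl)carbonyl)amino)methyl on this aromatic carbon gives an at least 1.5-fold higher number from compound 2 to compound 3 (0.18 log units; that floor lies within the scatter). The change therefore brings no lower number at this position, although the floor of the step lies within the scatter and its true size stays unfixed. The value of compound 3 is a limit and not a number: the limit of > 1000 nM in this assay, at which 1 of the 3 values shown sits.

The steps that start from compound 1 cannot be read, so the aminomethyl group adds no measured comparison here. On these data alone, how far the true value of compound 3 lies from that of compound 2 stays open. So does whether a carboxylic acid or an (acetylamino)methyl group on the same aromatic carbon would read closer to compound 2 or to compound 3.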